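The source may report more compounds than this note shows. Statements on the series, on what has been measured and on what is new or still open speak of the compounds shown alone.

Compound 1 `Cc1cc(CCC(=O)O)ccc1-c1noc(-c2ccc(OC(C)C)c(C#N)c2)n1`: 2.3 mL/min/kg
Compound 2 `Cc1cc(C(C)CC(=O)O)ccc1-c1noc(-c2ccc(OC(C)C)c(C(F)(F)F)c2)n1`: 2.9 mL/min/kg
Compound 3 `Cc1cc(CC(C)C(=O)O)ccc1-c1noc(-c2ccc(OC(C)C)c(C(F)(F)F)c2)n1`: 7 mL/min/kg

In an in vivo ADME assay on the whole organism (plasma, strain Sprague-Dawley) for pharmacokinetics, with Rattus norvegicus as the target (a higher number here means faster removal of the compound, a lower number slower removal), compound 3 gives 7 mL/min/kg, the highest of the three numbers, and the other two lie lower by more than the scatter. Compound 4 `Cc1cc(CCC(=O)O)ccc1-c1noc(-c2ccc(OC(C)C)c(C(F)(F)F)c2)n1` differs from it in one place: hydrogen in place of methyl on a saturated chain carbon bound to a carbonyl carbon and a saturated chain carbon. Put another way, 2-carboxypropyl becomes 2-carboxyethyl.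

Among the measured compounds shown here, only one measured step concerns this chain: a 2.4-fold higher number from compound 2 to compound 3 (0.38 log units; beyond the scatter). It is modest and shows that the form of the chain can move the number. For the measured compounds named here, no measured pair shows the methyl simply replaced by hydrogen, so the evidence is indirect. Compound 1 already carries 2-carboxyethyl, with nitrile in place of trifluoromethyl, and gives 2.3 mL/min/kg. That low value points the same way as the 2.9 mL/min/kg of compound 2.

A small move towards slower removal is therefore expected, not clearly larger than the scatter: a 1.8-fold lower number from compound 3 to compound 4 (0.27 log units; within the scatter). For compound 4 the estimate is 3.8 mL/min/kg, with an expected range of 1.7 mL/min/kg to 8.5 mL/min/kg.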

Compound 4, clearance: 8.7 mL/min/kg
Beside the measured number, compound 4's estimate is 2.3-fold (0.36 log units) below it; measured number outside the range, above it.
By their numbers in this assay, from the lowest: compounds 1 and 2 (each within the scatter of the next); then compounds 3 and 4 (each within the scatter of the next).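

In this assay, hydrogen in place of methyl on a saturated chain carbon bound to a carbonyl carbon and a saturated chain carbon leaves no readable change, with a 1.2-fold higher number from compound 3 to compound 4 (0.09 log units; within the scatter). The same swap on a saturated chain carbon bound to an aromatic carbon does register, with a 3.0-fold higher number from compound 2 to compound 4 (0.48 log units; beyond the scatter), so among these compounds the place of the methyl matters. Trifluoromethyl in place of cyano on an aromatic carbon gives a 3.8-fold higher number from compound 1 to compound 4 (0.58 log units; beyond the scatter), which shows that the 2-carboxyethyl chain does not by itself bring a low number, since that chain is shared by both compounds.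

Nothing measured alongside these numbers explains these steps. Going by these compounds, how a longer chain, or an amine in place of the carboxylic acid, would behave remains open.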